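Swapping a methyl-bearing ring for a trifluoromethyl-bearing ring

A few compounds are considered here, and "the series" means these few. Any claim that something is new, unique, unknown or untested is made for them only; others in the source may bear on it.

Compound 1 `O=C(Nc1cccc(/C=C/C(=O)c2nc3ccccc3[nH]2)c1)c1ccccc1`: in a functional assay on MCF7 cells (Homo sapiens) for antiproliferative activity, read by MTT assay, with a stated time of 48 h (on this read-out higher numbers stand for weaker inhibition and lower numbers for stronger inhibition), compound 1 gives 11200 nM.
Compound 2 `O=C(Nc1cccc(/C=C/C(=O)c2nc3ccccc3[nH]2)c1)c1cccc(Cl)c1`: compound 2 gives 7840 nM.
Compound 3 `Cc1ccc(C(=O)Nc2cccc(/C=C/C(=O)c3nc4ccccc4[nH]3)c2)cc1`: compound 3 gives 9690 nM.

All three compounds share the same core and differ only in the aromatic ring attached to the amide carbonyl. Compound 3 stands second highest of the three numbers, but the steps of a 1.2-fold lower number from compound 1 to compound 3 (0.06 log units; within the scatter) and a 1.2-fold higher number from compound 2 to compound 3 (0.09 log units; within the scatter) are both within the scatter, so the three values cannot be told apart. Compound 4 `O=C(Nc1cccc(/C=C/C(=O)c2nc3ccccc3[nH]2)c1)c1cccc(C(F)(F)F)c1` carries a further change on that ring: 3-(trifluoromethyl)phenyl in place of 4-methylphenyl on a carbonyl carbon. Going by the values given here, three measured steps bear on it: a 1.4-fold lower number from compound 1 to compound 2 (0.15 log units; within the scatter), a 1.2-fold lower number from compound 1 to compound 3 (0.06 log units; within the scatter) and a 1.2-fold higher number from compound 2 to compound 3 (0.09 log units; within the scatter). Each of them is within the scatter, and none of them shows a substituent on this ring moving the number in a reliable direction. On that basis compound 4 is expected to show a 1.1-fold lower number from compound 3 to compound 4 (0.06 log units; within the scatter), that is no change beyond the scatter. Compound 4 is therefore estimated at 8500 nM, with a range from 4000 nM to 18000 nM.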

Compound 4, half-maximal inhibitory concentration: 21500 nM
Estimate against measurement, compound 4: 2.5-fold (0.40 log units) below; measured number above the stated range.
By their numbers in this assay, from the lowest: compounds 2, 3, 1 and 4 (each within the scatter of the next, the first and the last beyond it).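

In this assay, going by these compounds alone, the ring on the amide carbonyl now shows steps beyond the scatter for the first time: a 2.2-fold higher number from compound 3 to compound 4 (0.35 log units; beyond the scatter) and a 2.7-fold higher number from compound 2 to compound 4 (0.44 log units; beyond the scatter) are both modest, and both point towards weaker inhibition. The ring is therefore not wholly indifferent to its substituent, as compounds 1 to 3 alone had suggested, although a 1.9-fold higher number from compound 1 to compound 4 (0.28 log units; within the scatter) means that compound 4 cannot be told apart from the unsubstituted compound 1, so it separates only from compounds 2 and 3. Nothing measured here accounts for this gap.

On these data alone, it remains open whether trifluoromethyl placed elsewhere on this ring would give a similar number. How a ring carrying an amine or a carboxylic acid would behave in this assay also remains an open question.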